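The source may hold more compounds than are shown below. What is called first, only, known or untested is meant among the compounds shown, and "the series" means these compounds.

Measured in a functional assay on HCT-116 cells (Homo sapiens) for antiproliferative activity, read by MTT assay; on this read-out higher numbers stand for weaker inhibition and lower numbers for stronger inhibition:
- compound 1 `Cn1c(=O)c(=O)n(C2CCCC2)c2nc(N/N=C/c3ccc(O)cc3)ncc21`: 72500 nM
- compound 2 `Cn1c(=O)c(=O)n(C2CCCC2)c2nc(N/N=C/c3ccco3)ncc21`: 78700 nM
- compound 3 `Cn1c(=O)c(=O)n(C2CCCC2)c2nc(N/N=C/c3cc([N+](=O)[O-])ccc3Cl)ncc21`: 5610 nM

Compound 1 belongs to the high, weakly inhibiting end of these numbers, level with compound 2 and well above compound 3. Compound 4 `Cn1c(=O)c(=O)n(C2CCCC2)c2nc(N/N=C/c3ccc(OC(F)(F)F)cc3)ncc21` keeps the core of compound 1 and changes one thing: trifluoromethyl in place of hydrogen on an oxygen on an aromatic ring. That is trifluoromethyl in place of hydrogen on an oxygen on an aromatic ring, or hydroxy to trifluoromethoxy.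

Within the data shown here, no measured step makes this exact change. The closest evidence comes from replacing the whole 4-hydroxyphenyl group. One such exchange gave a 1.1-fold higher number from compound 1 to compound 2 (0.04 log units; within the scatter), and the other gave a 13-fold lower number from compound 1 to compound 3 (1.11 log units; beyond the scatter). Both removed the hydroxy group, but only compound 3 at 5610 nM moved clearly, while compound 2 goes against any general gain. This supports only a modest lean towards stronger inhibition in this assay, with a step smaller than the large one. The expected outcome is a 2.4-fold lower number from compound 1 to compound 4 (0.38 log units; beyond the scatter). For compound 4 the estimated value is 30000 nM, with an expected range from 9000 nM to 90000 nM.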

Compound 4, half-maximal inhibitory concentration: 6150 nM
Compound 4: middle estimate off by 4.9-fold (0.69 log units), on the high side; measured number outside the range, below it.
By their numbers in this assay, from the lowest: compounds 3 and 4 (each within the scatter of the next); then compounds 1 and 2 (each within the scatter of the next).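

Compound 2 and compound 3 replaced the whole aromatic group, whereas here the ring stays and only the hydrogen on its oxygen gives way to trifluoromethyl; in this assay that single change is large, with a 12-fold lower number from compound 1 to compound 4 (1.07 log units; beyond the scatter) as its result. The hydrogen on this oxygen is therefore not needed for inhibition in these cells, and compound 4 at 6150 nM stands within the scatter of compound 3 at 5610 nM without carrying a chloro or a nitro group. Nothing measured here explains why this step is so large.

The compounds shown leave open whether a plain methyl on this oxygen, or a longer chain such as propyl, would give a step of similar size. They also leave open whether the trifluoromethyl itself matters, or whether any group on this oxygen would do.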